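From 4-methoxyphenyl to thiophen-2-yl: one swap, one estimate

The source may hold more compounds than are shown below. What is called first, only, known or untested is meant among the compounds shown, and "the series" means these compounds.

- compound 1 `COc1cc(C(=O)c2sc(-c3ccc(C)cc3)cc2N)cc(OC)c1OC` gives 16 nM
- compound 2 `COc1ccc(-c2cc(N)c(C(=O)c3cc(OC)c(OC)c(OC)c3)s2)cc1` gives 31 nM

In a functional assay on FM3A cells (Mus musculus) for antiproliferative activity (a lower number here means a stronger inhibitor, a higher number a weaker inhibitor), compound 2 stands at 31 nM and compound 1 at 16 nM as a pair within the scatter of each other, so the numbers do not rank them. Going on to compound 3 `COc1cc(C(=O)c2sc(-c3cccs3)cc2N)cc(OC)c1OC` makes one structural change thiophen-2-yl in place of 4-methoxyphenyl on an aromatic carbon that puts thiophen-2-yl in place of 4-methoxyphenyl on an aromatic carbon.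

Within the data shown here, only one measured step bears on this change. It is a 1.9-fold higher number from compound 1 to compound 2 (0.29 log units; within the scatter) for methoxy in place of methyl on an aromatic carbon, and it concerns the same group that now leaves. That step is small, but it alters only part of the group, whereas compound 3 exchanges all of it. Among the measured compounds shown here, no measured compound carries thiophen-2-yl, so the data give no direct guide and the range must stay wide.

An expected step of a 1.3-fold higher number from compound 2 to compound 3 (0.11 log units; within the scatter) is estimated, which means no firm shift beyond the scatter in this assay and no confident direction. For compound 3 the estimated value is 40 nM with an expected range from 12 nM to 150 nM in this assay.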

Compound 3, half-maximal inhibitory concentration: 1.7 nM
Estimate against measurement, compound 3: 24-fold (1.37 log units) above; the measured number lies below the stated range.
By their numbers in this assay, from the lowest: compound 3; then compounds 1 and 2 (each within the scatter of the next).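

The earlier pair, with 4-methylphenyl and 4-methoxyphenyl, stayed within the scatter of each other in this assay, so this position could have looked tolerant of change, but exchanging the whole group for thiophen-2-yl gives an 18-fold lower number from compound 2 to compound 3 (1.26 log units; beyond the scatter). The comparison with the other six-membered group points the same way, with a 9.4-fold lower number from compound 1 to compound 3 (0.97 log units; beyond the scatter), so the result does not rest on a single reference compound and shows that the group on this aromatic carbon, next to the ring sulfur, can move the number well beyond the scatter. Nothing available here shows why the number falls with this swap.

Thiophen-2-yl differs from the groups it replaces in several ways at once: it has a five-membered ring, it contains sulfur, and it lacks the small methyl or methoxy group, so the compounds shown cannot say which of these differences matters. Plain phenyl, furan-2-yl and thiophen-3-yl at this position would help to pull these differences apart, and it also remains open how a thiophen-2-yl carrying its own methyl group would behave.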